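The compounds below may be only part of what the source reports. "The series", "measured", "known", "first", "only" and "open" are said of these compounds alone.

Compound 1, `Oc1cccc(-c2ccc3c(-c4cncnc4)c(O)ccc3c2)c1`: 41%
Compound 2, `Oc1ccc2cc(-c3ccccc3)ccc2c1-c1cncnc1`: 22%
Compound 3, `Oc1ccccc1-c1ccc2c(-c3cncnc3)c(O)ccc2c1`: < 10%

These three compounds share one core and differ only in the group attached to it, and all were tested in an assay for binding affinity to 17-beta-hydroxysteroid dehydrogenase type 1 (Homo sapiens), read by scintillation counting, with a stated time of 10 min, tested at 1 uM; on this read-out lower numbers stand for less inhibition and higher numbers for more inhibition at the one concentration tested (going by the name of the read-out). Compound 3 gives only a limit in this assay, (the limit of < 10% in this assay, at which 1 of the 3 values shown sits), so its true reading is not a number but a value the assay could not resolve. Among the three, compound 3 therefore stands at the bottom of what was measured.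

Compound 4, `Oc1ccc(-c2ccc3c(-c4cncnc4)c(O)ccc3c2)cc1`, has not yet been measured. It differs from compound 3 in one place: 4-hydroxyphenyl in place of 2-hydroxyphenyl on an aromatic carbon. So the hydroxy group moves around the attached ring while nothing else changes.

Going by the values given here, two measured steps bear on this. Moving the hydroxy from one position to another cost heavily, a number at least 31 percentage points lower from compound 1 to compound 3 (beyond the scatter), and even removing it outright cost less, a number 19 percentage points lower from compound 1 to compound 2 (beyond the scatter). Adding it in the position of compound 3 lowered the reading further, a number at least 12 percentage points lower from compound 2 to compound 3 (beyond the scatter). The position of the hydroxy on the attached ring thus matters, and the position of compound 3 is the poorest of those seen. Moving it away from there is expected to raise inhibition, a number at least 20 percentage points higher from compound 3 to compound 4 (beyond the scatter), though whether a fresh position recovers as much as compound 1 cannot be known from these data.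

Compound 4 is therefore estimated at 30% in this assay, with a likely range from 10% to 55%.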

Compound 4, a percentage reported as inhibition, at one concentration (the size of the read-out at that concentration, not a potency): 35%
Compound 4: middle estimate off by 5 percentage points, on the low side, within the range that was stated.
By their numbers in this assay, from the lowest: compound 2; then compounds 4 and 1 (each within the scatter of the next). At a limit, below all of these: compound 3.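

In this assay, the plain phenyl of compound 2 now gains from a hydroxy in a second position, with a number 13 percentage points higher from compound 2 to compound 4 (beyond the scatter), which leaves 2-hydroxyphenyl as the only one of the three hydroxyphenyl groups shown that loses against plain phenyl. Exchanging that group for 4-hydroxyphenyl gives a number at least 25 percentage points higher from compound 3 to compound 4 (beyond the scatter), while the change from 3-hydroxyphenyl to 4-hydroxyphenyl gives a number 6 percentage points lower from compound 1 to compound 4 (within the scatter), so in these compounds the two groups cannot be told apart, and the same atoms joined differently set only 2-hydroxyphenyl apart. The step up from compound 3 has no fixed size, as compound 3 gives a limit and not a number: the limit of < 10% in this assay, at which 1 of the 4 values shown sits.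

Still open, from the compounds shown here alone, is what happens if the hydroxy of 4-hydroxyphenyl gives way to a methoxy, an amine or a carboxylic acid on the same ring, which would test whether the hydroxy itself is needed there. All these readings also come from a single concentration in this assay, so they give no potency for any of the compounds.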